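The source may report more compounds than this note shows. Statements on the series, on what has been measured and on what is new or still open speak of the compounds shown alone.

In a functional assay (Homo sapiens), tested at 10 uM (on this read-out lower numbers stand for a stronger effect and higher numbers for a weaker effect at the one concentration tested), compound 1, `O=C(CCCc1ccc(Cl)cc1)N1CCc2c(Cl)c(O)c(O)c(Cl)c2C1`, gives 16%. Compound 2, `O=C(CCCc1ccc(F)cn1)N1CCc2c(Cl)c(O)c(O)c(Cl)c2C1`, gives 25% in this assay, and compound 3, `O=C(CCCc1ccc(Cl)cn1)N1CCc2c(Cl)c(O)c(O)c(Cl)c2C1`, gives 15%. Among these three numbers compound 3 is the lowest, but its nearest neighbour is compound 1, and the step of a number 1 percentage points lower from compound 1 to compound 3 (within the scatter), like the step of a number 10 percentage points lower from compound 2 to compound 3 (within the scatter), stays within the scatter, so no order can be read among them. The step of a number 9 percentage points higher from compound 1 to compound 2 (within the scatter) is likewise within the scatter.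

Compound 4, `COc1ccc(CCCC(=O)N2CCc3c(Cl)c(O)c(O)c(Cl)c3C2)nc1`, is not yet measured in this assay. It differs from compound 3 as follows: methoxy in place of chloro on an aromatic carbon. Among the measured compounds shown here, the only measured step at the same place is the one from compound 2 to compound 3, where chloro replaced fluoro on that aromatic carbon, and that step was within the scatter. Methoxy in place of chloro has no measured counterpart here, so the direction is uncertain; the account expects no step beyond the scatter, with the estimated change being a number 7 percentage points higher from compound 3 to compound 4 (within the scatter) in this assay. Compound 4 is therefore estimated to give 22% in this assay, within a range from 10% to 40%.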

Compound 4, a percentage reported as activity, at one concentration (the size of the read-out at that concentration, not a potency): 31%
The estimate for compound 4 lay 9 percentage points below the measured number, within the range that was stated.
By their numbers in this assay, from the lowest: compounds 3, 1, 2 and 4 (each within the scatter of the next, the first and the last beyond it).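

Among the compounds shown here, at this aromatic carbon, two atoms from the ring nitrogen, the earlier compounds offered only chloro in place of fluoro, a step within the scatter; in this assay, methoxy in place of chloro gives the first step here beyond the scatter, a number 16 percentage points higher from compound 3 to compound 4 (beyond the scatter), a modest move towards a weaker effect at the one concentration tested. Measured against the 4-chlorophenyl group of compound 1, the 5-methoxypyridin-2-yl group also gives a modest step beyond the scatter, a number 15 percentage points higher from compound 1 to compound 4 (beyond the scatter), which neither the 5-chloropyridin-2-yl nor the 5-fluoropyridin-2-yl group did. The group at this place can therefore shift the read-out, though the picture is not a clean order, since methoxy in place of fluoro gives only a number 6 percentage points higher from compound 2 to compound 4 (within the scatter), so the fluoro and methoxy compounds cannot be told apart.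

Nothing measured for these compounds gives a reason for the methoxy step. Going by these compounds, it remains open whether an amine or a nitrile on this aromatic carbon would move the read-out further than methoxy, and whether a longer chain in place of the present one would alter the effect of these groups.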